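This account rests on a few compounds, and the source may have more. Where it says the series, first, only, none or still open, it means among the compounds named here.

The series shares one core, shown in compound 1 `O=C1c2ccccc2C(=O)N1CNc1ccc(F)cc1`, which carries fluorine on the outer six-membered ring. In an assay on isolated protein for inhibition of ribosomal protein S6 kinase alpha-2 (Homo sapiens), read by fluorescence, with a stated time of 20 min (on this read-out higher numbers stand for weaker inhibition and lower numbers for stronger inhibition), compound 1 gives 8740 nM, a weak result on this read-out. Compound 2 `CC(C)c1ccc(NCN2C(=O)c3ccccc3C2=O)cc1` carries isopropyl on that ring instead; in this assay compound 2 is recorded as "not determined" (no result reported), so where it stands cannot be placed on the scale at all. Compound 3 `O=C1c2ccccc2C(=O)N1CNc1ccc(O)cc1` is the compound still to be measured. It differs from compound 2 in one place: hydroxy in place of isopropyl on an aromatic carbon, in words hydroxy in place of isopropyl on an aromatic carbon, para to a large group. With no number for compound 2, the step to compound 3 cannot be sized or given a direction from the data; compound 1 is the only anchor, and it is weak. Compound 3 is expected to be weak as well, estimated at 10000 nM, with a range from 2500 nM to 40000 nM.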

Compound 3, half-maximal inhibitory concentration: 520 nM
Compound 3: middle estimate off by 19-fold (1.28 log units), on the high side; the whole stated range lies above it.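

Hydroxy in place of fluoro on this aromatic carbon, para to a large group, gives a 17-fold lower number from compound 1 to compound 3 (1.23 log units; beyond the scatter) in this assay. Within the data shown here, until now, the only number for this position was a weak one, whereas this result shows that a single group there can make a large difference and that the shared core can reach much stronger inhibition. Nothing measured here speaks to the reason for this gain.

Whether an amine or a methoxy on the same carbon would match hydroxy remains open, so the compounds shown cannot say how specific the gain is to hydroxy. As far as these compounds go, it is also open whether hydroxy would give a similar gain if another part of the shared core were changed.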